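Thiophene in Place of Methoxyphenyl on a Weak Inhibitor

This account rests on a few compounds, and the source may have more. Where it says the series, first, only, none or still open, it means among the compounds named here.

Compound 1 `COc1ccc(-c2cn(/N=C/c3cc4ccccc4nc3Cl)c(N)n2)cc1` is the simplest member of this small set. In a functional assay on DLD-1 cells (Homo sapiens) for cytotoxicity, read by MTT assay, with a stated time of 48 h (on this read-out higher numbers stand for weaker inhibition and lower numbers for stronger inhibition), compound 1 gives only the limit > 50000 nM, not a number. Compound 2 `COc1ccc(-c2cn(/N=C/c3cc4cc(C)ccc4nc3Cl)c(N)n2)cc1` carries a methyl in place of hydrogen on an aromatic carbon, and in this assay compound 2 gives 25700 nM, which corresponds to an at least 1.9-fold lower number from compound 1 to compound 2 (0.28 log units; that floor lies within the scatter). Compound 3 `Nc1nc(-c2ccc3ccccc3c2)cn1/N=C/c1cc2ccccc2nc1Cl` in this assay likewise gives only the limit > 50000 nM. Among the compounds with values here, compound 2 therefore stands as the sole compound with a number, while the other two sit at the limit of > 50000 nM in this assay, at which 2 of the 3 values shown sit.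

Compound 4 `Cc1ccc2nc(Cl)c(/C=N/n3cc(-c4cccs4)nc3N)cc2c1` differs from compound 2 by thiophen-2-yl in place of 4-methoxyphenyl on an aromatic carbon. Within the data shown here, no measured step concerns an exchange of this kind: the single step measured changes a different ring and stays within the scatter, and compound 3, which varies the same group on the unmethylated core, yields no number. The set offers no ground for a move beyond the scatter in this assay, and a limit rather than a number remains a real possibility. Compound 4 is expected to show a 1.4-fold higher number from compound 2 to compound 4 (0.13 log units; within the scatter). Compound 4 is accordingly estimated at 35000 nM, with a range from 12000 nM to 100000 nM.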

Compound 4, half-maximal inhibitory concentration: 8990 nM
Estimate against measurement, compound 4: 3.9-fold (0.59 log units) above; the measured number lies below the stated range.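

Within the data shown here, exchanging 4-methoxyphenyl for thiophen-2-yl gives a 2.9-fold lower number from compound 2 to compound 4 (0.46 log units; beyond the scatter) in this assay, the first step in the set that is read as beyond the scatter. This aromatic carbon of the five-membered ring therefore responds to the group it carries, and a group of 5 heavy atoms in place of one of 8 is compatible with a lower number. The earlier change at this position, from compound 1 to compound 3, cannot be read, and limits still make up much of the set: the limit of > 50000 nM in this assay, at which 2 of the 4 values shown sit.

On these data alone, whether thiophen-2-yl gives a similar step on the core of compound 1 remains open. Also open, as far as these compounds go, is whether the smaller ring or its sulfur accounts for the step, and how furan-2-yl or a phenyl ring bearing a carboxylic acid would read here.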